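The compounds below may be only part of what the source reports. "The series", "measured", "known", "first", "only" and "open" are said of these compounds alone.

Of the compounds shown here, three have been measured in an assay on isolated protein for displacement of a labelled ligand from Apoptosis regulator Bcl-2 (Homo sapiens), with a stated time of 15 min; a higher number here means a weaker inhibitor, a lower number a stronger inhibitor. For the measured compounds named here, compound 1 `CC1(C)CCC(CN2CCN(c3ccc(C(=O)NS(=O)(=O)c4ccc(NCC5CCOCC5)c([N+](=O)[O-])c4)c(Oc4cnc5[nH]ccc5c4)c3)CC2)=C(c2ccc(Cl)cc2C(F)(F)F)C1` gives 0.86 nM, and compound 2 `CC1(C)CCC(CN2CCN(c3ccc(C(=O)NS(=O)(=O)c4ccc(NCC5CCOCC5)c([N+](=O)[O-])c4)c(Oc4cnc5[nH]ccc5c4)c3)CC2)=C(c2ccc(C(F)(F)F)c(Cl)c2)C1` gives 0.8 nM; the only measured single-site step, a 1.1-fold lower number from compound 1 to compound 2 (0.03 log units; within the scatter), shows that swapping the substitution pattern of the chlorinated trifluoromethylphenyl ring makes no difference worth noting. Compound 3 `CCN(CC)CCCNc1ccc(S(=O)(=O)NC(=O)c2ccc(N3CCN(CC4=C(c5ccc(C(F)(F)F)cc5)CC(C)(C)CC4)CC3)cc2Oc2cnc3[nH]ccc3c2)cc1[N+](=O)[O-]` gives 0.3 nM, the lowest of the three numbers, and its gap to both compound 1 and compound 2 lies beyond the scatter.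

Compound 4 `CC1(C)CCC(CN2CCN(c3ccc(C(=O)NS(=O)(=O)c4ccc(OC5CCOCC5)c([N+](=O)[O-])c4)c(Oc4cnc5[nH]ccc5c4)c3)CC2)=C(c2ccc(C(F)(F)F)cc2)C1` differs from compound 3 in one place: (oxan-4-yl)oxy in place of (3-(diethylamino)propyl)amino on an aromatic carbon. Going by the values given here, no measured pair isolates this change. Compound 1 and compound 2 carry a different amino-linked chain at the same position, but they also carry other aryl groups, so their numbers say nothing direct about the chain alone. Among the compounds with values here, the one measured step concerns a different part of the molecule, so nothing supports expecting a large shift in this assay in either direction.

Compound 4 is therefore expected to sit close to compound 3, with the estimated step of a 2.0-fold higher number from compound 3 to compound 4 (0.30 log units; within the scatter), giving an expected value of 0.6 nM within a range of 0.25 nM to 1.5 nM.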

Compound 4, half-maximal inhibitory concentration: 8.4 nM
Estimate against measurement, compound 4: 14-fold (1.15 log units) below, and the stated range ends below it.
By their numbers in this assay, from the lowest: compound 3; then compounds 2 and 1 (each within the scatter of the next); then compound 4.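

For the compounds shown here, the only earlier step concerned the aryl ring at another part of the molecule, so this is the first sign that the aromatic carbon ortho to a nitro group and para to a large group matters in this assay: the change gives a 28-fold higher number from compound 3 to compound 4 (1.45 log units; beyond the scatter). Several things change together here, as a ringless chain with a hydrogen-bond donor and two nitrogens gives way to a six-membered non-aromatic ring with no donor, attached through oxygen. No measurement at hand explains why the number rises.

This single pair leaves open whether the linking atom, the ring or the diethylamino end accounts for the step. A (3-(diethylamino)propyl)oxy group, which puts the same chain on oxygen, and an (oxan-4-yl)amino group, which puts the same ring on nitrogen, would begin to separate these features.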